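The source may report more compounds than this note shows. Statements on the series, on what has been measured and on what is new or still open speak of the compounds shown alone.

Measured in a functional assay on LOX IMVI cells (Homo sapiens) for cytotoxicity, read by MTT assay, with a stated time of 24 h; on this read-out higher numbers stand for weaker inhibition and lower numbers for stronger inhibition:
- compound 1 `COc1cc(-c2nc(-c3ccccc3)[nH]c2-c2ccnc(NCCCNS(=O)(=O)c3cccc(F)c3)n2)ccc1Cl`: 5110 nM
- compound 2 `O=S(=O)(NCCCNc1nccc(-c2[nH]c(-c3ccccc3)nc2-c2ccc(Cl)c(O)c2)n1)c1ccccc1`: 2630 nM
- compound 3 `O=S(=O)(NCCCNc1nccc(-c2[nH]c(-c3ccccc3)nc2-c2ccc(Cl)c(O)c2)n1)c1ccc(F)cc1`: 2300 nM

In this assay, compound 3 gives 2300 nM and lies within the scatter of compound 2. Compound 1 shows a higher number, 5110 nM, which places it beyond the scatter of compound 3.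

The next comparison is compound 4 `O=S(=O)(NCCCNc1nccc(-c2[nH]c(-c3ccccc3)nc2-c2ccc(Cl)c(O)c2)n1)c1cccc(F)c1`, which has not yet been measured. The structural change is 3-fluorophenyl in place of 4-fluorophenyl on a sulfonyl sulfur. In words, 3-fluorophenyl stands in place of 4-fluorophenyl on a sulfonyl sulfur.

For the measured compounds named here, no measured pair tests this exchange on its own. The closest evidence is a 1.1-fold lower number from compound 2 to compound 3 (0.06 log units; within the scatter), where fluoro replaces hydrogen on an aromatic carbon. That single step says little about a move between the two fluorophenyl groups, but it gives no sign of a large response at this part of the series.

No shift beyond the scatter is therefore expected in this assay, and no direction can be supported. The estimate stays close to compound 3 at 2300 nM. The expected change is small, a 1.0-fold higher number from compound 3 to compound 4 (0.02 log units; within the scatter). Compound 4 is estimated at 2400 nM, with an expected range of 1300 nM to 4400 nM.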

Compound 4, half-maximal inhibitory concentration: 33600 nM
The estimate for compound 4 lay 14-fold (1.15 log units) below the measured number; the whole stated range lies below it.
By their numbers in this assay, from the lowest: compounds 3, 2 and 1 (each within the scatter of the next, the first and the last beyond it); then compound 4.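

In this assay, the group on the sulfonyl sulfur proves sensitive to where its fluoro sits: 3-fluorophenyl in place of 4-fluorophenyl gives a 15-fold higher number from compound 3 to compound 4 (1.16 log units; beyond the scatter), a large step between groups with the same atoms, whereas the earlier fluoro for hydrogen exchange gave only a 1.1-fold lower number from compound 2 to compound 3 (0.06 log units; within the scatter). Fluoro in place of hydrogen therefore has no single outcome in this series, since the same kind of exchange gives a 13-fold higher number from compound 2 to compound 4 (1.11 log units; beyond the scatter), and with 3-fluorophenyl held constant, hydrogen in place of methyl on the oxygen gives a 6.6-fold higher number from compound 1 to compound 4 (0.82 log units; beyond the scatter), so the group on that oxygen also changes the number in this sulfonamide. Nothing available accounts for either step.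

From the compounds shown here alone, it remains open whether the step belongs to fluoro alone or would also appear with 3-chlorophenyl or 3-methoxyphenyl on the sulfonyl sulfur, and where 2-fluorophenyl would fall. Going by these compounds, the response to methyl on the oxygen also remains open for the phenyl and 4-fluorophenyl sulfonamides, where only the hydroxy form is available for reading.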